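Replacing the Whole Amide Arm of a Shared Core

This account rests on a few compounds, and the source may have more. Where it says the series, first, only, none or still open, it means among the compounds named here.

Measured so far in a physicochemical assay for lipophilicity, at pH 7.4; a higher number here means a more lipophilic compound, a lower number a more polar compound:
compound 1 `Cc1cc(C(=O)Nc2c(F)cccc2F)nn1Cc1cc(Cl)ccc1OCc1ccccc1`: 3.7
compound 2 `Cc1cc(C(=O)NCc2ccccn2)nn1Cc1cc(Cl)ccc1OCc1ccccc1`: > 3.7 (a limit of the assay, not a number)
compound 3 `Cc1cc(C(=O)NCc2cccnc2)nn1Cc1cc(Cl)ccc1OCc1ccccc1`: > 3.7 (a limit of the assay, not a number)

The three measured compounds share one core and differ only in the group on the amide-type nitrogen. Compound 1 gives a plain number. Compound 3 stands at the upper limit of this assay, so its true value is open. Consequently a number no lower from compound 1 to compound 2 (the limit leaves the size open) and a number no lower from compound 1 to compound 3 (the limit leaves the size open) are unreadable in size, and a step that the two limits leave unreadable from compound 2 to compound 3 cannot be read at all; the limit of > 3.7 in this assay, at which 2 of the 3 values shown sit, is the reason.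

Compound 4 `Cc1cc(NC(=O)C2CCOCC2)nn1Cc1cc(Cl)ccc1OCc1ccccc1` has not been measured. It differs from compound 3 in one place: ((oxan-4-yl)carbonyl)amino in place of ((pyridin-3-yl)methyl)carbamoyl on an aromatic carbon. For the measured compounds named here, none of the measured steps bears on this change: all of them keep the carbamoyl group and vary only what sits on its nitrogen, whereas here the carbamoyl group itself leaves and an ((oxan-4-yl)carbonyl)amino group enters. Going by the values given here, no measured step therefore gives a direction or a size to expect.

The expectation rests on the shared core alone. Compound 4 is expected to give about 3.4, within 2.8 to 4. That estimate corresponds to an expected step of a number at least 0.30 log units lower from compound 3 to compound 4 (that floor lies within the scatter), though with compound 3 at a limit the step itself stays uncertain.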

Compound 4, distribution coefficient: > 3.7
Compound 4: no number, only a limit; the forecaster's own chance of this, stated with the estimate: 20%; middle value at least 0.30 log units from the limit.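

In this assay compound 4 gives > 3.7, which is a limit of the assay and not a number. The earlier compounds shown here varied only what sits on the nitrogen of the carbamoyl group, whereas compound 4 shows that replacing the whole arm at this aromatic carbon, with ((oxan-4-yl)carbonyl)amino in place of ((pyridin-3-yl)methyl)carbamoyl, also gives no plain number. For the compounds shown here, only one new step has a direction, and a number no lower from compound 1 to compound 4 (the limit leaves the size open) is that step. None of the new steps to compound 4 can be read in size, and the cause is the ceiling of the assay: the limit of > 3.7 in this assay, at which 3 of the 4 values shown sit.

On these data alone, whether compound 4 truly lies higher or lower than compound 2 or compound 3 therefore stays open, as does the size of its distance from compound 1. Also open, as far as these compounds go, is whether an arm carrying a carboxylic acid or an amine at this aromatic carbon would give a plain number in this assay.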